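Amide side chain variation: methyl on the phenyl ring

The source may report more compounds than this note shows. Statements on the series, on what has been measured and on what is new or still open speak of the compounds shown alone.

Measured so far in a functional assay on RKE cells for antagonist activity at Vasoactive intestinal polypeptide receptor 1 (Rattus norvegicus), read by HTRF and cAMP accumulation, with stated times of 10 min and 30 min; a lower number here means a stronger inhibitor, a higher number a weaker inhibitor:
compound 1 `CC(C)CC(=O)Nc1sc2c(c1C#N)CCCC2` gives 1900 nM
compound 2 `N#Cc1c(NC(=O)CCc2ccccc2)sc2c1CCCC2` gives 290 nM

For the measured compounds named here, compound 2 stands lowest of the two numbers; the only step mapped is a 6.6-fold lower number from compound 1 to compound 2 (0.82 log units; beyond the scatter), the replacement of isopropyl by benzyl on the chain carbon bound to the carbonyl carbon.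

Compound 3 `Cc1cccc(CCC(=O)Nc2sc3c(c2C#N)CCCC3)c1` differs from compound 2 by methyl in place of hydrogen on an aromatic carbon; the place is an aromatic carbon of the six-membered aromatic ring of carbon only, meta to a large group. Going by the values given here, no measured step bears on substitution of this ring: the one known step concerns the chain and not the ring, so it gives no direction for a methyl there. With one heavy atom entering, no step beyond the scatter is expected in this assay. For compound 3 the expected step is a 1.2-fold lower number from compound 2 to compound 3 (0.06 log units; within the scatter). Compound 3 is estimated at 250 nM, with a range from 80 nM to 800 nM.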

Compound 3, half-maximal inhibitory concentration: 750 nM
For compound 3 the middle estimate is 3.0-fold (0.48 log units) below the measured one; the range from low to high includes it.
By their numbers in this assay, from the lowest: compound 2; then compound 3; then compound 1.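

In this assay the aromatic ring of the side chain proves sensitive to substitution: phenyl to 3-methylphenyl gives a 2.6-fold higher number from compound 2 to compound 3 (0.41 log units; beyond the scatter) with the entry of one carbon. For the compounds shown here, this is the first reading on the ring itself, and it points towards a weaker inhibitor, so a methyl at this aromatic carbon is not accommodated without cost. Nothing available on these compounds accounts for the step.

From the compounds shown here alone, whether the step belongs to methyl alone or to any group at this place stays open, and a methoxy group or a chlorine atom on the same aromatic carbon would separate those readings. Also open, going by these compounds, are methyl on the other carbons of this ring and a longer chain between the carbonyl and the ring.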